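Cyclopentyl in place of (pyrrolidin-1-yl)methyl

The source may hold more compounds than are shown below. What is called first, only, known or untested is meant among the compounds shown, and "the series" means these compounds.

In an ADME assay on NIH3T3 cells (Mus musculus) for cytotoxicity (on this read-out lower numbers stand for higher toxicity in this test and higher numbers for lower toxicity in this test), compound 1 (`CN(C)CC#Cc1cc2ncnc(Nc3ccc(OCc4cccc(F)c4)c(Cl)c3)c2s1`) returns only a limit of the assay, not a number (> 50 uM). Among the measured compounds shown here, compound 2 (`Fc1cccc(COc2ccc(Nc3ncnc4cc(C#CCN5CCCC5)sc34)cc2Cl)c1`) reads 6.4 uM in this assay and is the only compound so far with an actual number.

Compound 3 (`Fc1cccc(COc2ccc(Nc3ncnc4cc(C#CC5CCCC5)sc34)cc2Cl)c1`) keeps the shared core and differs from compound 2 in one place, on a triple-bonded carbon (cyclopentyl in place of (pyrrolidin-1-yl)methyl on a triple-bonded carbon). There cyclopentyl stands in place of (pyrrolidin-1-yl)methyl, so the nitrogen of that group leaves.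

For the measured compounds named here, one measured step bears on this change: an at least 7.8-fold lower number from compound 1 to compound 2 (0.89 log units; beyond the scatter). It shows that the read-out in this assay can move beyond the scatter when only this side chain is altered. Going by the values given here, no measured step removes the nitrogen, however, so the direction of the next step rests on thin evidence. Compound 2 holds the lower of the two readings, so a move back towards higher numbers seems somewhat more likely than a further fall. The expected step is a 2.3-fold higher number from compound 2 to compound 3 (0.37 log units; beyond the scatter), modest and uncertain. The estimate for compound 3 is 15 uM (expected range 4 uM to 50 uM).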

Compound 3, half-maximal toxic concentration: > 100 uM
Compound 3 ended at the assay's limit (the forecaster's own chance of this, stated with the estimate: 30%); middle value at least 6.6-fold (0.82 log units) away from the limit.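

Swapping (pyrrolidin-1-yl)methyl for cyclopentyl on a triple-bonded carbon gives, in this assay, an at least 15-fold higher number from compound 2 to compound 3 (1.19 log units; beyond the scatter), the first measured change here that takes the nitrogen out of the side chain, and the step is large. Compound 3 ends at a limit of the assay rather than at a number, so the step gives only a minimum size: the limit of > 100 uM in this assay, at which 1 of the 3 values shown sits. The low number therefore stays with compound 2 alone among the three, yet the nitrogen cannot account for it by itself, since compound 1 keeps a nitrogen in this side chain and also ends at a limit, and the step from compound 1 to compound 3 cannot be read, both ends being limits.

The compounds shown leave open whether the low number in compound 2 follows the pyrrolidine ring or the combination of ring and nitrogen, and a piperidin-1-ylmethyl or morpholin-4-ylmethyl group on the same carbon would bear on this. On these data alone, how a cyclohexyl group or an open butyl chain would read there also remains open.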